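Removing the benzyl ring from a cytotoxic isatin core

This account rests on a few compounds, and the source may have more. Where it says the series, first, only, none or still open, it means among the compounds named here.

Compound 1 `COC(=O)/C=C/c1ccc2c(c1)C(=O)C(=O)N2Cc1ccc(C)cc1` is the reference point here. In a functional assay on HepG2 cells (Homo sapiens) for cytotoxicity, read by MTT assay, with a stated time of 48 h (on this read-out higher numbers stand for weaker inhibition and lower numbers for stronger inhibition), compound 1 gives 40 nM, the lowest of the three numbers measured. Compound 2 `COC(=O)/C=C/c1ccc2c(c1)C(=O)C(=O)N2Cc1ccc(C(F)(F)F)cc1` gives 70 nM, and the step of a 1.8-fold higher number from compound 1 to compound 2 (0.24 log units; within the scatter). Compound 3 `CCCCOC(=O)/C=C/c1ccc2c(c1)C(=O)C(=O)N2Cc1ccc(Br)cc1` differs from compound 1 in two places at once. In this assay compound 3 gives 650 nM, a much higher number.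

Compound 4 `COC(=O)/C=C/c1ccc2c(c1)C(=O)C(=O)N2C` is not yet measured. The change from compound 1 is hydrogen in place of 4-methylphenyl on a saturated chain carbon bound to an amide-type nitrogen in a ring. Among the compounds with values here, no measured step covers this change: the one step available, from compound 1 to compound 2, only swapped a group on the 4-methylphenyl ring that compound 4 loses entirely, and stayed within the scatter. Removing the whole seven-carbon group is a larger change than anything measured, so the direction is open, though compound 3 shows that reworking this side of the molecule together with the ester gave a higher number. Compound 4 is therefore expected to give a higher number, with the step of a 10-fold higher number from compound 1 to compound 4 (1.00 log units; beyond the scatter), and an estimated value of 400 nM within the range 80 nM to 2000 nM.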

Compound 4, half-maximal inhibitory concentration: 530 nM
The estimate for compound 4 lay 1.3-fold (0.12 log units) below the measured number; the measured number falls inside the stated range.
By their numbers in this assay, from the lowest: compounds 1 and 2 (each within the scatter of the next); then compounds 4 and 3 (each within the scatter of the next).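

Replacing 4-methylphenyl with hydrogen at this position gives a 13-fold higher number from compound 1 to compound 4 (1.12 log units; beyond the scatter) in this assay, so the low number of compound 1 is not carried by the shared core alone. Within the data shown here, the only earlier step with a single change, a 1.8-fold higher number from compound 1 to compound 2 (0.24 log units; within the scatter), altered a group on that ring while leaving the ring in place; the new step shows that losing the whole ring matters far more in this small set. Nothing given here explains this loss.

A hexyl chain or a cyclohexyl ring at this position could help separate the need for an aromatic ring from the need for a large carbon group. From the compounds shown here alone, the separate contribution of the butyl ester also stays open, since compound 3 differs from compound 1 in two places at once.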